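The source may report more compounds than this note shows. Statements on the series, on what has been measured and on what is new or still open speak of the compounds shown alone.

Compound 1 `CC1CCN(C2CCN(S(=O)(=O)c3cccc(C(F)(F)F)c3)CC2)CC1` in an ADME assay on HCT-116 cells (Homo sapiens) for cytotoxicity, read by CellTiter-Glo, with a stated time of 72 h (a higher number here means a weaker inhibitor, a lower number a stronger inhibitor), gives > 5000 nM, a limit of the measurement rather than a number.
Compound 2 `CC1CCN(C2CCN(S(=O)(=O)c3cccc(Cl)c3)CC2)CC1` in this assay gives > 5000 nM, likewise a limit rather than a number.

Both measured values sit at the same limit, (the limit of > 5000 nM in this assay, at which 2 of the 2 values shown sit), so compound 2 stands at the weak end of what this assay can report, with no exact number to place it. Within the data shown here, the only measured step, a step that the two limits leave unreadable from compound 1 to compound 2, cannot be read in size for the same reason, and it concerns a different exchange. The untested compound 3 `Cc1ccc(-c2cccc(S(=O)(=O)N3CCC(N4CCC(C)CC4)CC3)c2)cc1` differs from compound 2 by 4-methylphenyl in place of chloro on an aromatic carbon. Among the measured compounds shown here, no measured step in this set bears on that change, and with both known values at the limit there is no direction to read off. The expected step is therefore a step that the limit leaves unreadable from compound 2 to compound 3, meaning nothing beyond the scatter, though with wide uncertainty since the starting point is itself only a limit. Compound 3 is thus estimated at 8000 nM, within a range from 2000 nM to 30000 nM, most probably again reported only as a limit.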

Compound 3, half-maximal inhibitory concentration: > 5000 nM
Compound 3 ended at the assay's limit (the forecaster's own chance of this, stated with the estimate: 70%); the middle value is on the limit's open side.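

Compound 1, compound 2 and compound 3 all end at a limit of the measurement rather than at a number, so no step among them can be read in size: the limit of > 5000 nM in this assay, at which 3 of the 3 values shown sit.

As far as these compounds go, what remains open is whether trifluoromethyl, chloro and 4-methylphenyl differ at all in this assay, and which change to the shared core would give a readable number.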